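A few compounds are considered here, and "the series" means these few. Any claim that something is new, unique, unknown or untested is made for them only; others in the source may bear on it.

Of the compounds shown here, two have been measured in an assay on NIH3T3 cells with Urotensin-2 receptor (Homo sapiens) as the target; on this read-out lower numbers stand for smaller maximal responses and higher numbers for larger maximal responses. Compound 1, with the structure `Cc1ccsc1C(=O)OC(CCN(C)C)c1ccc(Cl)cc1`, gives 119% in this assay. Compound 2, with the structure `CN(C)CCC(OC(=O)c1ccc(C(F)(F)F)cc1)c1ccc(Cl)cc1`, gives 47% in this assay. Of these two numbers, compound 1 stands highest, and the nearest number, that of compound 2, lies far below it, by more than the usual scatter. The two compounds differ in more than one place, so their gap cannot be tied to a single change.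

Compound 3, with the structure `Cc1cccc(C(=O)OC(CCN(C)C)c2ccc(Cl)cc2)c1C`, has not yet been measured in this assay. It differs from compound 1 in one place: 2,3-dimethylphenyl in place of 3-methylthiophen-2-yl on a carbonyl carbon. Among the compounds with values here, no measured pair differs by exactly this change, so the size of the step cannot be read from the data. A moderate fall is expected from compound 1 to compound 3, a number 24 percentage points lower from compound 1 to compound 3 (beyond the scatter), because compound 2, which also carries a six-membered carbon ring on the carbonyl carbon, gives 47%. Compound 3 is therefore estimated at 95%, with a range from 50% to 135%.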

Compound 3, largest response reached (reported as efficacy), in percent of the reference or control that the assay uses: 91%
Compound 3: middle estimate off by 4 percentage points, on the high side; the measured number falls inside the stated range.
By their numbers in this assay, from the lowest: compound 2; then compound 3; then compound 1.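

In this assay, within the data shown here, the change from 3-methylthiophen-2-yl to 2,3-dimethylphenyl on the carbonyl carbon gives the first step that can be tied to a single place: a number 28 percentage points lower from compound 1 to compound 3 (beyond the scatter). The position therefore does respond to the group it carries, yet a six-membered aromatic ring of carbon only still leaves a sizeable maximal response, with compound 3 at 91%. This one swap alters the ring size, the sulfur atom and the methyl count together, and no measurement shown here explains the step or assigns it to any one of these.

Still open, going by these compounds, is which part of the swap matters: a plain phenyl or an unsubstituted thiophen-2-yl on the carbonyl carbon would test the methyl groups, and a 3-methylfuran-2-yl would test the sulfur atom. Also unknown is whether a step of this size would hold elsewhere in the series, for instance with fluorine in place of the chlorine of the shared core.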